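Methyl for cyclopropyl on the sulfonyl sulfur

The source may hold more compounds than are shown below. What is called first, only, known or untested is meant among the compounds shown, and "the series" means these compounds.

In an ADME assay for permeability, using PAMPA, at pH 5.5 (on this read-out lower numbers stand for lower permeability and higher numbers for higher permeability), compound 3 `Cn1cc(-c2ccc(C(F)(F)F)cc2)c2ccc(C(=O)NS(=O)(=O)C3CC3)cc21` gives 525 nm/s, the lower of the two numbers available. Compound 2 `Cn1cc(-c2ccc(C(F)(F)F)cc2)c2cc(F)c(C(=O)NS(=O)(=O)C3CC3)cc21` gives 1660 nm/s. Compound 1 `CC(C)Cc1ccc(-c2cn(C)c3cc(C(=O)NS(C)(=O)=O)ccc23)cc1` also carries the (methylsulfonyl)carbamoyl group, but its entry reads "not determined" (no result reported), so it offers no number for comparison.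

The step under consideration leads to compound 4 `Cn1cc(-c2ccc(C(F)(F)F)cc2)c2ccc(C(=O)NS(C)(=O)=O)cc21`: methyl in place of cyclopropyl on a sulfonyl sulfur, with methyl in place of cyclopropyl on a sulfonyl sulfur. Going by the values given here, the only measured step is a 3.2-fold lower number from compound 2 to compound 3 (0.50 log units; beyond the scatter), which is hydrogen in place of fluoro on an aromatic carbon. It is a different change, so it indicates only the size a single small change can reach in this series. Among the compounds with values here, no measured pair covers the sulfonyl sulfur, and the expected direction is therefore a judgement, not a finding. For compound 4 the expected step is modest and downward, estimated as a 2.3-fold lower number from compound 3 to compound 4 (0.36 log units; beyond the scatter). Compound 4 is estimated at 230 nm/s, with an expected range of 90 nm/s to 550 nm/s.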

Compound 4, apparent permeability: 972 nm/s
Compound 4: middle estimate off by 4.2-fold (0.63 log units), on the low side, outside the stated range (above it).
By their numbers in this assay, from the lowest: compounds 3, 4 and 2 (each within the scatter of the next, the first and the last beyond it).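

In this assay, the sulfonyl sulfur now has its first measured pair: methyl in place of cyclopropyl gives a 1.9-fold higher number from compound 3 to compound 4 (0.27 log units; within the scatter). On this one pair, the two groups on a sulfonyl sulfur cannot be told apart in this assay, with the rest of the structure held the same. Among the steps shown, only hydrogen in place of fluoro on an aromatic carbon, a 3.2-fold lower number from compound 2 to compound 3 (0.50 log units; beyond the scatter), lies beyond the scatter, and no measurement available here bears on the reason for the new result.

From the compounds shown here alone, whether methyl and cyclopropyl would also read alike with the fluoro of compound 2 present remains open. Going by these compounds, only those two groups stand on the sulfonyl sulfur here, so an amine or a longer chain at that place remains open too.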